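This account rests on a few compounds, and the source may have more. Where it says the series, first, only, none or still open, it means among the compounds named here.

Compound 1 `C#CCNC1CCc2c(SCCc3cccc(C(F)(F)F)c3)cccc21`: 3720 nM
Compound 2 `C#CCNC1CCc2c(SCCc3cccc(Br)c3)cccc21`: 30500 nM

Among the measured compounds shown here, in an assay on isolated protein for inhibition of Amine oxidase [flavin-containing] B (Homo sapiens) (on this read-out lower numbers stand for stronger inhibition and higher numbers for weaker inhibition), compound 2 gives 30500 nM, the higher of the two measured numbers; its only neighbour is compound 1, which in this assay gives 3720 nM. For the measured compounds named here, the single measured step is an 8.2-fold higher number from compound 1 to compound 2 (0.91 log units; beyond the scatter), a bromo in place of trifluoromethyl on an aromatic carbon.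

Compound 3 `C#CCNC1CCc2c(SCCc3ccc(F)c(F)c3)cccc21` differs from compound 2 by 3,4-difluorophenyl in place of 3-bromophenyl on a saturated chain carbon, two bonds along the chain from a sulfur. Going by the values given here, no measured step covers this exact change. The step from compound 1 to compound 2 bears on it only loosely: it shows that the bromo-bearing ring of compound 2 is the weaker of the two measured aryl groups, so replacing it is more likely to lower the number than to raise it, but the size is uncertain. The expected step is a 3.1-fold lower number from compound 2 to compound 3 (0.48 log units; beyond the scatter). Compound 3 is therefore estimated at 10000 nM, with a range of 3000 nM to 35000 nM.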

Compound 3, half-maximal inhibitory concentration: 3240 nM
Compound 3: middle estimate off by 3.1-fold (0.49 log units), on the high side, and the stated range covers the measured number.
By their numbers in this assay, from the lowest: compounds 3 and 1 (each within the scatter of the next); then compound 2.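

The change of 3-bromophenyl to 3,4-difluorophenyl on a saturated chain carbon, two bonds along the chain from a sulfur, gives a 9.4-fold lower number from compound 2 to compound 3 (0.97 log units; beyond the scatter) in this assay, so this position responds strongly to a change of aryl substituents that leaves the rest of the molecule intact. Compound 1 at 3720 nM and compound 3 at 3240 nM lie within the scatter of each other, which shows that a single trifluoromethyl and two fluorines on this ring give values that cannot be told apart, and that among these three compounds only compound 2 stands apart. Nothing given here accounts for this step.

On these data alone, it remains open whether one fluorine alone would match the two in compound 3. The compounds shown also do not tell how an unsubstituted phenyl, a methoxy group on the ring or a longer chain would read here.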